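Thiazolyl-thiazolidinone series: paw edema notes

The source may report more compounds than this note shows. Statements on the series, on what has been measured and on what is new or still open speak of the compounds shown alone.

Measured compounds:
compound 1 `Cc1nc(-c2ccc(Cl)cc2)sc1C1SCC(=O)N1c1ccc(F)c(Cl)c1` gives 45.2%
compound 2 `COc1ccc(N2C(=O)CSC2c2sc(-c3ccccc3)nc2C)cc1` gives 48.2%

In a functional assay on the whole organism (strain Wistar albino) for inhibition, with Rattus norvegicus as the target, read by paw edema, with stated times of 1 h and 2 h, at a dose of 40 mg/kg by the oral route (on this read-out lower numbers stand for less inhibition and higher numbers for more inhibition at the one dose given (going by the name of the read-out)), compound 2 gives 48.2%, the higher of the two numbers, with compound 1 nearest at 45.2%; the two values lie within the scatter of each other, so no order between them can be read.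

Compound 3 `Cc1nc(-c2ccccc2)sc1C1SCC(=O)N1c1ccc(F)c(Cl)c1` has not yet been measured. It differs from compound 2 by 3-chloro-4-fluorophenyl in place of 4-methoxyphenyl on an amide-type nitrogen in a ring. Compound 1 already carries the 3-chloro-4-fluorophenyl on the amide-type nitrogen in a ring and sits within the scatter of compound 2, so both measured numbers point to the same narrow band. Among the measured compounds shown here, no step between measured compounds is known for this change, and nothing in the data suggests a shift beyond the scatter in either direction.

Compound 3 is therefore expected to give about 46%, with a range from 36% to 56%; the estimated step from a number 2.2 percentage points lower from compound 2 to compound 3 (within the scatter) is expected to stay within the scatter.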

Compound 3, a percentage reported as inhibition, in the whole organism at one dose (the size of the read-out at that dose, not a potency): 20.9%
Estimate against measurement, compound 3: 25.1 percentage points above; the whole stated range lies above it.
By their numbers in this assay, from the lowest: compound 3; then compounds 1 and 2 (each within the scatter of the next).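

In this assay, 3-chloro-4-fluorophenyl in place of 4-methoxyphenyl on the amide-type nitrogen in a ring gives a number 27.3 percentage points lower from compound 2 to compound 3 (beyond the scatter) and shows that this position is not indifferent to the aryl group it carries. Hydrogen in place of chloro on an aromatic carbon gives a number 24.3 percentage points lower from compound 1 to compound 3 (beyond the scatter) with the 3-chloro-4-fluorophenyl group unchanged, so the reading with that group differs with the chloro elsewhere in the molecule. Among the compounds shown here, compound 1 and compound 2 differ in two places, and their close values gave no sign of either step.

No measurement shown bears on why the number falls. Still open, on these data alone, is whether 4-methoxyphenyl on the same nitrogen responds in the same way to the chloro, and how a dimethylamino group or a carboxylic acid on that aryl ring would read.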